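Extending the Ethyl Side Chain with a Pyridyl Ring

A few compounds are considered here, and "the series" means these few. Any claim that something is new, unique, unknown or untested is made for them only; others in the source may bear on it.

Compound 1 `CCn1nc(-c2ccnc(Nc3ccc(S(N)(=O)=O)cc3)n2)c2ccccc21` carries a sulfamoyl group on the aniline and gives the lowest number of the three measured compounds: in a functional assay on MCF7 cells (Homo sapiens) for antiproliferative activity, read by MTT assay, with a stated time of 72 h (on this read-out higher numbers stand for weaker inhibition of growth and lower numbers for stronger inhibition of growth), compound 1 gives 2280 nM. Compound 2 `CCn1nc(-c2ccnc(Nc3ccc([N+](=O)[O-])cc3)n2)c2ccccc21`, with a nitro group in that position, gives 24000 nM in this assay, a change of an 11-fold higher number from compound 1 to compound 2 (1.02 log units; beyond the scatter). Compound 3 `CCn1nc(-c2ccnc(Nc3ccc(O)cc3)n2)c2ccccc21`, with a hydroxy group, gives 5780 nM, a change of a 2.5-fold higher number from compound 1 to compound 3 (0.40 log units; beyond the scatter); from the nitro to the hydroxy compound the shift is a 4.2-fold lower number from compound 2 to compound 3 (0.62 log units; beyond the scatter).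

Compound 4 `NS(=O)(=O)c1ccc(Nc2nccc(-c3nn(Cc4cccnc4)c4ccccc34)n2)cc1` keeps the sulfamoyl aniline of compound 1 and instead alters the chain on the ring nitrogen of the shared core: pyridin-3-yl in place of methyl on a saturated chain carbon bound to an aromatic nitrogen. None of the three measured steps touches this part of the molecule; all of them vary the aniline substituent, so they give no direct guide to the size or direction of the change in this assay. With nothing to suggest a shift beyond the usual scatter, the step from compound 1 to compound 4 is expected to be about a 1.1-fold lower number from compound 1 to compound 4 (0.06 log units; within the scatter). Compound 4 is therefore estimated to give about 2000 nM in this assay, with a likely range from 600 nM to 7000 nM.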

Compound 4, concentration for 50% growth inhibition: 2630 nM
Estimate against measurement, compound 4: 1.3-fold (0.12 log units) below; the measured number falls inside the stated range.
By their numbers in this assay, from the lowest: compounds 1 and 4 (each within the scatter of the next); then compound 3; then compound 2.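

Among these compounds, with the chain on the ring nitrogen of the shared core changed for the first time, the result in this assay is a 1.2-fold higher number from compound 1 to compound 4 (0.06 log units; within the scatter), so compound 1 and compound 4 cannot be told apart on this read-out. This step exchanges methyl, 1 heavy atom, for pyridin-3-yl, 6 heavy atoms with one six-membered aromatic ring and 1 hydrogen-bond acceptor, on a saturated chain carbon bound to an aromatic nitrogen, and even so it stays within the scatter, unlike the aniline step an 11-fold higher number from compound 1 to compound 2 (1.02 log units; beyond the scatter). Nothing in the data shown accounts for this result.

The compounds shown leave open whether this place would accept other groups in the same way, such as a phenyl ring, a primary amine, a carboxylic acid or a longer chain ending in a pyridine ring. Among the compounds shown here, they also leave open whether (pyridin-3-yl)methyl in place of ethyl would give a similar step with the nitro or hydroxy aniline of compound 2 and compound 3, since here it is seen only with the sulfamoyl aniline.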